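The source may hold more compounds than are shown below. What is called first, only, known or untested is meant among the compounds shown, and "the series" means these compounds.

Going by the values given here, in a toxicity assay on MT4 cells (Homo sapiens) for cytotoxicity, read by MTT assay, with a stated time of 5 days (a lower number here means that less compound is tolerated, a higher number that more compound is tolerated), compound 2 (`Cc1cc(-c2cc(C)c(Nc3ccnc(Nc4ccc(C#N)cc4)n3)c(C)c2)cc(C)n1`) gives 2300 nM as the lower of the two numbers so far, while compound 1 (`Cc1cc(-c2ccnc(F)c2)cc(C)c1Nc1ccnc(Nc2ccc(C#N)cc2)n1`) gives 6000 nM as the higher one. Compound 3 (`Cc1ncc(-c2cc(C)c(Nc3ccnc(Nc4ccc(C#N)cc4)n3)c(C)c2)cn1`) carries 2-methylpyrimidin-5-yl in place of 2,6-dimethylpyridin-4-yl (2-methylpyrimidin-5-yl in place of 2,6-dimethylpyridin-4-yl on an aromatic carbon). Among the compounds with values here, only one measured step bears on this exchange, a modest one (a 2.6-fold lower number from compound 1 to compound 2 (0.42 log units; beyond the scatter)) that gives no firm direction for a new group. With compound 2 at the low end, the expected step in this assay is small and points toward a higher number (a 1.7-fold higher number from compound 2 to compound 3 (0.24 log units; within the scatter)). Compound 3 is estimated at 4000 nM with 1500 nM to 10000 nM as the expected range.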

Compound 3, half-maximal cytotoxic concentration: 3900 nM
Compound 3: middle estimate off by 1.0-fold (0.01 log units), on the high side; measured number inside the range.
By their numbers in this assay, from the lowest: compounds 2, 3 and 1 (each within the scatter of the next, the first and the last beyond it).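

On an aromatic carbon para to a large group, 2-methylpyrimidin-5-yl, a ring with 2 hetero atoms, replaces 2,6-dimethylpyridin-4-yl (a 1.7-fold higher number from compound 2 to compound 3 (0.23 log units; within the scatter)) and 2-fluoropyridin-4-yl (a 1.5-fold lower number from compound 1 to compound 3 (0.19 log units; within the scatter)). In this assay, compound 3 therefore cannot be told apart from either of the other two compounds, even though those two lie beyond the scatter of each other. No measurement shown here explains these numbers. On these data alone, all three groups at this position are six-membered aromatic rings, so what an amine or a carboxylic acid would give in their place stays open.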